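The compounds below may be only part of what the source reports. "The series", "measured", "known", "first", "only" and "open" are said of these compounds alone.

In a functional assay on the whole organism with Rattus norvegicus as the target (on this read-out lower numbers stand for an effect already at smaller amounts and higher numbers for an effect only at larger amounts of compound), compound 2 (`CCCOc1ccccc1-c1ncc(-c2nn[nH]n2)c(O)n1`) gives 0.04 mg/kg and holds the lower of the two numbers, while compound 1 (`Oc1nc(-c2ccccc2)ncc1-c1nn[nH]n1`) gives 100 mg/kg as the other. The change to compound 3 (`CCCCOc1ccccc1-c1ncc(-c2nn[nH]n2)c(O)n1`) is methyl in place of hydrogen on a saturated chain carbon, three bonds along the chain from an oxygen on an aromatic ring and reads propyl to butyl when cut further out. Going by the values given here, the only measured step, a 2500-fold lower number from compound 1 to compound 2 (3.40 log units; beyond the scatter) and large, put propoxy in place of hydrogen on an aromatic carbon and shows nothing on chain length. In this assay a step within the scatter is therefore expected, leaning to a higher number, with a 1.8-fold higher number from compound 2 to compound 3 (0.24 log units; within the scatter) as the estimate. For compound 3 the estimated value is 0.07 mg/kg (0.015 mg/kg to 0.4 mg/kg).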

Compound 3, dose for 50% inhibition: 0.07 mg/kg
Estimate against measurement, compound 3: no gap at the digits printed, within the range that was stated.
By their numbers in this assay, from the lowest: compounds 2 and 3 (each within the scatter of the next); then compound 1.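

In this assay, going from propyl to butyl gives a 1.8-fold higher number from compound 2 to compound 3 (0.24 log units; within the scatter), so methyl is tolerated on this saturated chain carbon, three bonds along the chain from an oxygen on an aromatic ring, and the two compounds cannot be told apart. Butoxy in place of hydrogen on the aromatic carbon also gives a large step, a 1400-fold lower number from compound 1 to compound 3 (3.15 log units; beyond the scatter), so this effect is not confined to propoxy. No evidence on the origin of these results is at hand. From the compounds shown here alone, whether a longer chain such as pentyl stays level remains open. So does the outcome for a chain ending in an amine or a carboxylic acid.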